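The source may report more compounds than this note shows. Statements on the series, on what has been measured and on what is new or still open speak of the compounds shown alone.

Compound 1 `Oc1cccc(-c2cc(-c3ccccc3F)cc(-c3ccccc3O)n2)c1`: 31100 nM
Compound 2 `Oc1cccc(-c2cc(-c3cccc(C(F)(F)F)c3)cc(-c3ccccc3O)n2)c1`: 19500 nM

Of the compounds shown here, two have been tested in a functional assay on HeLa cells (Homo sapiens) for inhibition; a lower number here means a stronger inhibitor, a higher number a weaker inhibitor. Compound 1 gives 31100 nM and compound 2 gives 19500 nM. Compound 2 thus shows the lower of the two numbers, but a 1.6-fold lower number from compound 1 to compound 2 (0.20 log units; within the scatter) lies within the usual scatter, so the two cannot be told apart on these values.

Compound 3 `Oc1cccc(-c2cc(-c3ccc(C(F)(F)F)cc3)cc(-c3ccccc3O)n2)c1` has not yet been measured in this assay. It is built from the same atoms as compound 2, joined differently: 4-(trifluoromethyl)phenyl in place of 3-(trifluoromethyl)phenyl on an aromatic carbon. The trifluoromethyl group is simply moved to another carbon of the same phenyl ring that hangs on the shared core.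

Among the compounds with values here, only one measured step touches this position, the one from compound 1 to compound 2, in which a different ring replaced the one carried there; it gave a 1.6-fold lower number from compound 1 to compound 2 (0.20 log units; within the scatter), within the scatter. Nothing measured here separates one placement of the trifluoromethyl group from another, so no step beyond the scatter is expected: no change at the digits printed from compound 2 to compound 3 (within the scatter). Compound 3 is therefore estimated at 19500 nM, with a range from 6000 nM to 60000 nM.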

Compound 3, half-maximal inhibitory concentration: > 50000 nM
Compound 3: only a limit was reported; the forecaster's own chance of this, stated with the estimate: 10%; middle value at least 2.5-fold (0.40 log units) from the limit.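

In this assay, compound 3 carries only a limit of the assay and not a true number: the limit of > 50000 nM in this assay, at which 1 of the 3 values shown sits.

Even so, 4-(trifluoromethyl)phenyl in place of 3-(trifluoromethyl)phenyl gives an at least 2.5-fold higher number from compound 2 to compound 3 (0.40 log units; beyond the scatter). The two groups hold the same atoms, so this pair shows that where the trifluoromethyl group sits on this phenyl ring can matter here, something the earlier step between two different rings could not show. The other new step, an at least 1.6-fold higher number from compound 1 to compound 3 (0.20 log units; that floor lies within the scatter), has a floor that does not clear the usual scatter, so it does not separate those two compounds.

As far as these compounds go, the real size of the step to compound 3 stays open, as the limit fixes only one end of it, and these three compounds show a single shift of one group on one ring rather than a rule for this position. Also open, from the compounds shown here alone, is whether a phenyl ring carrying an amine or a carboxylic acid in place of the trifluoromethyl group would read like compound 2 or like compound 3.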